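The source may hold more compounds than are shown below. What is called first, only, known or untested is meant among the compounds shown, and "the series" means these compounds.

Compound 2 `C=CC(=O)Nc1cccc(NC(=O)CSc2nc(Nc3cccc(F)c3)c3ccccc3n2)c1` gives 2030 nM in a functional assay on NCI-H1975 cells (Homo sapiens) for inhibition, read by MTT assay, with a stated time of 72 h (on this read-out higher numbers stand for weaker inhibition and lower numbers for stronger inhibition), the lower of the two numbers in hand. Within the data shown here, compound 1 `O=C(CSc1nc(Nc2ccccc2)c2ccccc2n1)Nc1ccc(Cl)cc1` gives 8040 nM in this assay; its structure differs from compound 2 in more than one place, so no single step is read between the two, only the gap between their values. Compound 3 `C=CC(=O)Nc1cccc(NC(=O)CSc2nc(Nc3ccc(C(F)(F)F)cc3)c3ccccc3n2)c1` carries 4-(trifluoromethyl)phenyl in place of 3-fluorophenyl on a nitrogen on an aromatic ring. Among the measured compounds shown here, no measured step of this kind exists in the set, so the expected step is small, at most a modest shift toward weaker inhibition: a 1.3-fold higher number from compound 2 to compound 3 (0.11 log units; within the scatter). Compound 3 is estimated at 2600 nM in this assay, with a range from 900 nM to 8000 nM.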

Compound 3, half-maximal inhibitory concentration: 12900 nM
Compound 3: middle estimate off by 5.0-fold (0.70 log units), on the low side; measured number outside the range, above it.
By their numbers in this assay, from the lowest: compound 2; then compounds 1 and 3 (each within the scatter of the next).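

In this assay the group on the nitrogen on an aromatic ring proves to matter: 4-(trifluoromethyl)phenyl in place of 3-fluorophenyl gives a 6.4-fold higher number from compound 2 to compound 3 (0.80 log units; beyond the scatter) and this lies beyond the scatter. This position therefore responds to a change of aryl group, and this change weakens inhibition. Nothing in hand gives a reason for the loss.

Open, as far as these compounds go, is whether the loss follows the trifluoromethyl group itself or the place it holds on the phenyl ring. From the compounds shown here alone, how a methoxy group or an amine on that ring would read also remains open.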